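The compounds below may be only part of what the source reports. "The series", "measured", "known", "first", "only" and "open" are said of these compounds alone.

Measured in a functional assay on A549 cells (Homo sapiens) for cytotoxicity, read by MTT assay; a lower number here means a stronger inhibitor, a higher number a weaker inhibitor:
- compound 1 `COC(=O)C[C@@H]1C[C@@H](O)[C@H](C)[C@H](c2ccccc2)N1`: 8500 nM
- compound 2 `C[C@H]1[C@H](O)C[C@@H](CCO)N[C@H]1c1ccccc1`: 31200 nM

Among the measured compounds shown here, of the two compounds measured so far, compound 2 has the higher number, at 31200 nM, and is therefore the weaker inhibitor. The next change gives compound 3 `C[C@H]1[C@H](O)C[C@@H](CC(=O)O)N[C@H]1c1ccccc1`, with carboxy in place of hydroxymethyl on a saturated chain carbon bound to a saturated ring carbon. For the measured compounds named here, only one measured step bears on this change. It acts at the same place and reads a 3.7-fold higher number from compound 1 to compound 2 (0.56 log units; beyond the scatter), a modest step beyond the scatter. Going by the values given here, that step replaced methoxycarbonyl with hydroxymethyl, so it offers only an indirect guide, and no compound with carboxy has been measured yet. With a single step to draw on, only a small move in this assay is expected, leaning towards a higher number and possibly staying within the scatter. The step expected is a 1.4-fold higher number from compound 2 to compound 3 (0.16 log units; within the scatter). The estimated value for compound 3 is 45000 nM, with an expected range of 15000 nM to 130000 nM.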

Compound 3, half-maximal inhibitory concentration: 28900 nM
Beside the measured number, compound 3's estimate is 1.6-fold (0.19 log units) above it, within the range that was stated.
By their numbers in this assay, from the lowest: compound 1; then compounds 3 and 2 (each within the scatter of the next).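

In this assay, carboxy in place of hydroxymethyl on a saturated chain carbon bound to a saturated ring carbon gives a 1.1-fold lower number from compound 2 to compound 3 (0.03 log units; within the scatter), so this position does not separate the 2-hydroxyethyl and carboxymethyl chains, despite the added carbonyl oxygen. Hydrogen in place of methyl on an oxygen next to a carbonyl group gives a 3.4-fold higher number from compound 1 to compound 3 (0.53 log units; beyond the scatter), a step beyond the scatter that matches a 3.7-fold higher number from compound 1 to compound 2 (0.56 log units; beyond the scatter) in reading against the free carboxy and hydroxymethyl groups alike. Among these three compounds, only the methoxycarbonyl of compound 1 stands apart at this position, and no supporting data give a reason for that difference.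

On these data alone, whether the lower number of compound 1 depends on the methyl on that oxygen or would hold for other carbonyl derivatives stays open, and an ethyl ester or a primary amide at this place would bear on that. As far as these compounds go, it is also open how far the flat reading of compounds 2 and 3 extends, which an amine or a longer chain ending in a carboxylic acid could test.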